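The compounds below may be only part of what the source reports. "The series", "measured", "known", "first", "only" and "open" are said of these compounds alone.

Compound 1 `Oc1cccc(-c2cc(-c3ccccc3O)nc(-c3ccccc3O)c2)c1`: 5020 nM
Compound 2 `Oc1ccc(-c2cc(-c3cccc(O)c3)cc(-c3ccccc3O)n2)cc1`: > 50000 nM (a limit)

These values come from a functional assay on HCT-15 cells (Homo sapiens) for cytotoxicity, read by CCK-8 assay, with a stated time of 4 days; on this read-out higher numbers stand for weaker inhibition and lower numbers for stronger inhibition. Compound 2 has no number, only a limit of the assay, (the limit of > 50000 nM in this assay, at which 1 of the 2 values shown sits). Compound 3 `Oc1ccc(-c2cc(-c3ccc(O)cc3)nc(-c3ccccc3O)c2)cc1` differs from compound 2 by one change, 4-hydroxyphenyl in place of 3-hydroxyphenyl on an aromatic carbon: 4-hydroxyphenyl in place of 3-hydroxyphenyl, opposite the ring nitrogen. For the measured compounds named here, one measured step bears on this, also a change to 4-hydroxyphenyl: an at least 9.9-fold higher number from compound 1 to compound 2 (0.99 log units; beyond the scatter), beyond the scatter. With that group entering again, a high number is expected to persist. The expected step is small, an at least 2.0-fold lower number from compound 2 to compound 3 (0.30 log units; that floor lies within the scatter). Compound 3 is estimated at 25000 nM, with an expected range of 6000 nM to 50000 nM.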

Compound 3, half-maximal inhibitory concentration: > 50000 nM
Compound 3 gave a limit, no number (the forecaster's own chance of this, stated with the estimate: 40%); middle value at least 2.0-fold (0.30 log units) away from the limit.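

Compound 3, like compound 2, gives only a limit, so the step between them cannot be read: the limit of > 50000 nM in this assay, at which 2 of the 3 values shown sit.

The compounds shown leave open whether 4-hydroxyphenyl and 3-hydroxyphenyl differ at all in this position opposite the ring nitrogen.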